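Replacing chloro with methylamino on the shared core

The source may report more compounds than this note shows. Statements on the series, on what has been measured and on what is new or still open speak of the compounds shown alone.

Measured in a functional assay on cells (Mast cell, Rattus norvegicus) for inhibition, with a stated time of 15 min; on this read-out lower numbers stand for an effect already at smaller amounts and higher numbers for an effect only at larger amounts of compound:
- compound 1 `O=C(Nc1nnn[nH]1)c1cc(=O)c2ccccc2o1`: 0.08 ug/mL
- compound 2 `Cc1c(C(=O)Nc2nnn[nH]2)oc2ccccc2c1=O`: 0.4 ug/mL
- compound 3 `O=C(Nc1nnn[nH]1)c1oc2ccccc2c(=O)c1Cl`: 0.8 ug/mL

Compound 3 lies within the scatter of compound 2, and its number is higher than that of compound 1. Compound 4 `CNc1c(C(=O)Nc2nnn[nH]2)oc2ccccc2c1=O` has methylamino in place of chloro on an aromatic carbon. For the measured compounds named here, three measured steps concern this carbon. Methyl gave a 5.0-fold higher number from compound 1 to compound 2 (0.70 log units; beyond the scatter), and chloro gave a 10-fold higher number from compound 1 to compound 3 (1.00 log units; beyond the scatter). Exchanging those two groups gave a 2.0-fold higher number from compound 2 to compound 3 (0.30 log units; within the scatter). Neither replacement of the hydrogen lowered the number, but no measurement covers methylamino. A further exchange at this carbon is therefore expected to stay within the scatter in this assay, with wide uncertainty. The expected step is a 1.3-fold higher number from compound 3 to compound 4 (0.10 log units; within the scatter). For compound 4, the estimated value is 1 ug/mL, within an expected range of 0.2 ug/mL to 5 ug/mL.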

Compound 4, concentration for half-maximal effect: 0.4 ug/mL
Compound 4: middle estimate off by 2.5-fold (0.40 log units), on the high side; low and high end bracket the measured number.
By their numbers in this assay, from the lowest: compound 1; then compounds 2, 4 and 3 (each within the scatter of the next).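

In this assay, methylamino on this aromatic carbon gives a 2.0-fold lower number from compound 3 to compound 4 (0.30 log units; within the scatter) and no change at the digits printed from compound 2 to compound 4 (within the scatter) with no separation from chloro or methyl, even though it adds a hydrogen-bond donor and a hydrogen-bond acceptor. The hydrogen of compound 1 remains apart from all three groups, with methylamino giving a 5.0-fold higher number from compound 1 to compound 4 (0.70 log units; beyond the scatter) as the newest case. No supporting data explain why these three groups fall together or why they differ from hydrogen.

Still open, going by these compounds, is whether any group at this carbon can match hydrogen. Fluoro, hydroxy, dimethylamino or a carboxylic acid would test this.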